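The source may hold more compounds than are shown below. What is called first, only, known or untested is meant among the compounds shown, and "the series" means these compounds.

Working notes on the series. Among the compounds with values here, in a functional assay on SK-BR-3 cells (Homo sapiens) for inhibition, read by MTT assay (on this read-out lower numbers stand for stronger inhibition of growth and higher numbers for weaker inhibition of growth), compound 1 (`CC1=C(/C=C/C(C)=C/C=C/C(C)=C\C(=O)NCc2cccc(F)c2)C(C)(C)CCC1n1ccnc1`) gives 4240 nM, the lower of the two numbers so far, and compound 2 (`CC1=C(/C=C/C(C)=C/C=C/C(C)=C\C(=O)Nc2cccc(F)c2)C(C)(C)CCC1n1ccnc1`) gives 17000 nM. Compound 3 (`CC1=C(/C=C/C(C)=C/C=C/C(C)=C\C(=O)Nc2ccccc2O)C(C)(C)CCC1n1ccnc1`) has not yet been measured. It differs from compound 1 by 2-hydroxyphenyl in place of 3-fluorobenzyl on an amide-type nitrogen.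

Within the data shown here, only one measured step bears on this change: a 4.0-fold higher number from compound 1 to compound 2 (0.60 log units; beyond the scatter). That modest step, beyond the scatter, replaces the same 3-fluorobenzyl group with 3-fluorophenyl. Compound 3, like compound 2, carries a phenyl group rather than a benzyl group on that nitrogen. Among the measured compounds shown here, no measured compound carries the 2-hydroxyphenyl group, however, so the contribution of the hydroxy group is unknown and the size of the step remains uncertain. A modest step to a higher number in this assay is therefore expected, in the same direction as the step seen with compound 2, possibly somewhat smaller. The expected step is a 2.6-fold higher number from compound 1 to compound 3 (0.41 log units; beyond the scatter). For compound 3 the estimated value is 11000 nM, with an expected range of 3500 nM to 30000 nM.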

Compound 3, concentration for 50% growth inhibition: 3890 nM
The estimate for compound 3 lay 2.8-fold (0.45 log units) above the measured number; the range from low to high includes it.
By their numbers in this assay, from the lowest: compounds 3 and 1 (each within the scatter of the next); then compound 2.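

In this assay, a phenyl group carried directly on the amide-type nitrogen does not by itself raise the number, as the earlier step to compound 2 alone might have suggested: a 1.1-fold lower number from compound 1 to compound 3 (0.04 log units; within the scatter). Between the two phenyl compounds the substituted ring does make a difference, with a 4.4-fold lower number from compound 2 to compound 3 (0.64 log units; beyond the scatter), so the higher number of compound 2 belongs to the 3-fluorophenyl group and not to every phenyl group at this place. No data at hand account for the gap between these two phenyl groups.

The 3-fluorophenyl and 2-hydroxyphenyl groups differ in both the substituent and its place on the ring, so the compounds shown cannot separate the effect of swapping fluorine for hydroxy from the effect of moving it. A 3-hydroxyphenyl, 2-fluorophenyl or 2-methoxyphenyl group would bear on that question, and a 2-hydroxybenzyl group would show whether the hydroxy group changes the number on the benzyl side of the series.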